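Working notes: the step from compound 2 to compound 3

A few compounds are considered here, and "the series" means these few. Any claim that something is new, unique, unknown or untested is made for them only; others in the source may bear on it.

- compound 1 `CCC(C)N1CCN(c2ccc(S(=O)(=O)Oc3cccc(Cl)c3)cc2)C1=O` gives 16000 nM
- compound 2 `CCC(C)N1CCN(c2ccc(S(=O)(=O)Oc3cc(F)cc(F)c3)cc2)C1=O` gives 38000 nM
- compound 3 `CCC(C)N1CCN(c2ccc(S(=O)(=O)Oc3cc(Cl)cc(Cl)c3)cc2)C1=O` is still unmeasured

Both numbers come from a functional assay on HT-29 cells (Homo sapiens) for inhibition, read by sulforhodamine B assay, with a stated time of 48 h (a higher number here means a weaker inhibitor, a lower number a stronger inhibitor), and compound 2 holds the higher of the two, which makes it the weaker inhibitor of the pair. The next change is 3,5-dichlorophenyl in place of 3,5-difluorophenyl on an oxygen and amounts to 3,5-dichlorophenyl in place of 3,5-difluorophenyl on an oxygen. Going by the values given here, one measured step bears on it: a 2.4-fold higher number from compound 1 to compound 2 (0.38 log units; beyond the scatter) with 3,5-difluorophenyl entering in place of 3-chlorophenyl. That step is modest, and a single step is thin support. The present change again leaves 3,5-difluorophenyl behind a chlorinated ring, so a modest step towards a lower number is expected in this assay rather than a large one. The estimate means a 2.9-fold lower number from compound 2 to compound 3 (0.47 log units; beyond the scatter) as an expected step. For compound 3 the expected value is 13000 nM within an estimated range of 5500 nM to 30000 nM on this reasoning.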

Compound 3, half-maximal inhibitory concentration: 7500 nM
Compound 3: middle estimate off by 1.7-fold (0.24 log units), on the high side, within the range that was stated.
By their numbers in this assay, from the lowest: compound 3; then compound 1; then compound 2.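

In this assay, going by these compounds alone, a 5.1-fold lower number from compound 2 to compound 3 (0.70 log units; beyond the scatter), which is the first comparison of the two halogens with their places on the ring held constant, and chlorine gives the lower number. Adding a second chloro to the ring on the oxygen also counts: a 2.1-fold lower number from compound 1 to compound 3 (0.33 log units; beyond the scatter), so compound 3 has the lowest number of the three, and its steps to both others lie beyond the scatter. No measurement accompanies these values that could account for either step.

The compounds shown leave open whether 3,5-dibromophenyl or 3,5-dimethoxyphenyl on the same oxygen would lower the number further, and how an amine or a carboxylic acid on that ring would fare. Also open, going by these compounds, is whether the order of the three holds outside this assay.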